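Swapping the acid arm for a pyrrolidine ring

The source may hold more compounds than are shown below. What is called first, only, known or untested is meant among the compounds shown, and "the series" means these compounds.

Measured compounds:
compound 1 `O=P(O)(O)OCc1nc(Nc2ccc(C(F)(F)F)cc2)c2ccc(-c3ncccc3C(F)(F)F)cc2n1` — 46 nM
compound 2 `O=C(O)COCc1nc(Nc2ccc(C(F)(F)F)cc2)c2ccc(-c3ncccc3C(F)(F)F)cc2n1` — 81 nM
compound 3 `OCCCc1nc(Nc2ccc(C(F)(F)F)cc2)c2ccc(-c3ncccc3C(F)(F)F)cc2n1` — 25 nM

All three compounds share one core and differ only in the group on a saturated chain carbon bound to an aromatic carbon. In a functional assay for antagonist activity at transient receptor potential cation channel subfamily V member 1 (Homo sapiens) (on this read-out lower numbers stand for stronger inhibition and higher numbers for weaker inhibition), compound 2 gives the highest of the three numbers. Its nearest neighbour is compound 1, with a 1.8-fold higher number from compound 1 to compound 2 (0.25 log units; within the scatter) separating them, a gap within the scatter. Its furthest neighbour is compound 3, reached by a 3.2-fold lower number from compound 2 to compound 3 (0.51 log units; beyond the scatter), a gap beyond the scatter.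

Compound 4 `FC(F)(F)c1ccc(Nc2nc(CN3CCCC3)nc3cc(-c4ncccc4C(F)(F)F)ccc23)cc1` has not yet been measured. It differs from compound 2 by pyrrolidin-1-yl in place of carboxymethoxy on a saturated chain carbon bound to an aromatic carbon. The step from compound 2 to compound 3 bears most on this change, as it also removes carboxymethoxy from the same carbon and was modest in size. The step from compound 1 to compound 2 stayed within the scatter. Within the data shown here, no measured compound carries a pyrrolidin-1-yl group, so that part of the change has no direct precedent here.

For compound 4 a modest step toward a lower number is expected, roughly a 2.0-fold lower number from compound 2 to compound 4 (0.31 log units; beyond the scatter). The estimate for compound 4 in this assay is 40 nM, with a range from 12 nM to 130 nM.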

Compound 4, half-maximal inhibitory concentration: 25 nM
The estimate for compound 4 lay 1.6-fold (0.20 log units) above the measured number; measured number inside the range.
By their numbers in this assay, from the lowest: compounds 3, 4, 1 and 2 (each within the scatter of the next, the first and the last beyond it).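

In this assay, among these compounds, the place on a saturated chain carbon bound to an aromatic carbon accepts a ring: putting pyrrolidin-1-yl in place of carboxymethoxy brings a 3.2-fold lower number from compound 2 to compound 4 (0.51 log units; beyond the scatter), a modest step of the same printed size as the one to the 2-hydroxyethyl group of compound 3. The two replacements cannot be told apart, with no change at the digits printed from compound 3 to compound 4 (within the scatter), so an open chain and a five-membered ring with a nitrogen read alike at this place, even though the ring has 0 hydrogen-bond donors. The phosphorus-bearing group of compound 1 also stays close, with a 1.8-fold lower number from compound 1 to compound 4 (0.26 log units; within the scatter), which leaves compound 2 set apart from compound 3 and compound 4 but not from compound 1.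

Nothing measured on these compounds gives a reason for these numbers. As far as these compounds go, whether a piperidine ring, a morpholine ring or an open dimethylamine would read the same at this place remains open, as does the effect of a longer chain carrying the pyrrolidine ring.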